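The source may report more compounds than this note shows. Statements on the series, on what has been measured and on what is new or still open speak of the compounds shown alone.

Measured compounds:
Compound 1 `c1ccc2c(c1)CN[C@@H](CN(CCCCNCC1CCCCC1)[C@H]1CCCc3cccnc31)C2` gives 158 nM in a functional assay on cells for antagonist activity at C-X-C chemokine receptor type 4 (Homo sapiens), read by fluorescence and calcium flux, with stated times of 25 min and 90 s; a higher number here means a weaker inhibitor, a lower number a stronger inhibitor.
Compound 2 `O=S1(=O)CCC(CNCCCCN(C[C@H]2Cc3ccccc3CN2)[C@H]2CCCc3cccnc32)CC1` gives 17 nM in this assay.
Compound 3 `c1ccc2c(c1)CN[C@@H](CN(CCCCNC1CCSCC1)[C@H]1CCCc3cccnc31)C2` gives 54.7 nM in this assay.

Compound 3 holds the middle place of the three: its number is higher than that of compound 2 by a 3.2-fold higher number from compound 2 to compound 3 (0.51 log units; beyond the scatter) and lower than that of compound 1 by a 2.9-fold lower number from compound 1 to compound 3 (0.46 log units; beyond the scatter). All three measured steps change the same end of the molecule, the group on a saturated chain carbon bound to an amine nitrogen, and they span sizes from a 2.9-fold lower number from compound 1 to compound 3 (0.46 log units; beyond the scatter) to a 9.3-fold lower number from compound 1 to compound 2 (0.97 log units; beyond the scatter).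

Compound 4 `C(=C/CN(C[C@H]1Cc2ccccc2CN1)[C@H]1CCCc2cccnc21)\CNCc1ccccn1` changes that same end: a group of 11 heavy atoms (9 carbon, 2 nitrogen; one six-membered aromatic ring with 1 hetero atom) in place of a group of 10 heavy atoms (8 carbon, 1 nitrogen, 1 sulfur; one six-membered non-aromatic ring with 1 hetero atom), on a saturated chain carbon bound to an amine nitrogen. Among the compounds with values here, no measured step introduces an aromatic ring or a double bond outside aromatic rings there, so the direction is not fixed by the data. What the measured steps do show is that this end of the molecule moves the number by modest amounts in either direction, so a step of similar size is expected for a 1.8-fold lower number from compound 3 to compound 4 (0.26 log units; within the scatter), with a slight lean toward a lower number given that both departures from compound 1 lowered it. Compound 4 is therefore estimated at 30 nM in this assay, within a range of 8 nM to 120 nM.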

Compound 4, half-maximal inhibitory concentration: 58.3 nM
Beside the measured number, compound 4's estimate is 1.9-fold (0.29 log units) below it; the measured number falls inside the stated range.
By their numbers in this assay, from the lowest: compound 2; then compounds 3 and 4 (each within the scatter of the next); then compound 1.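

In this assay, a six-membered aromatic ring with 1 hetero atom, entering together with 1 double bond outside aromatic rings, is accepted on a saturated chain carbon bound to an amine nitrogen: the change gives a 1.1-fold higher number from compound 3 to compound 4 (0.03 log units; within the scatter) and, against the carbon-only ring, a 2.7-fold lower number from compound 1 to compound 4 (0.43 log units; beyond the scatter). Aromatic and non-aromatic rings carrying a hetero atom can therefore stand at this end of the molecule without a step beyond the scatter between the thian-4-yl and aromatic groups, and all three groups with a hetero atom in the ring, in compound 2, compound 3 and compound 4, give lower numbers than the carbon-only ring of compound 1, with no compound shown going against this. No measurement among those available explains this result.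

The entering group brings the aromatic ring and the double bond together, so the compounds shown do not separate the contribution of each. Also open, on these data alone, is how a phenyl ring, with carbon only, or a piperidine ring carrying an amine nitrogen would compare at this place.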